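Bromo to 2,6-dimethylphenyl: notes on compound 4

A few compounds are considered here, and "the series" means these few. Any claim that something is new, unique, unknown or untested is made for them only; others in the source may bear on it.

Measured in an ADME assay on BJ cells (Homo sapiens) for cytotoxicity, read by luminescence, with a stated time of 72 h; on this read-out higher numbers stand for an effect only at larger amounts of compound and lower numbers for an effect already at smaller amounts:
- Compound 1 `CCOC(=O)c1c(-c2cccc(Oc3ccccc3)c2)[nH]c2cc(OC)c(F)cc2c1=O` gives > 21500 nM, a limit.
- Compound 2 `CCOC(=O)c1c(-c2cccc(F)c2)[nH]c2cc(OC)c(F)cc2c1=O` gives > 21500 nM, a limit.
- Compound 3 `CCOC(=O)c1c(-c2cccc(Br)c2)[nH]c2cc(OC)c(F)cc2c1=O` gives > 21500 nM, a limit.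

Compound 3 therefore has no number, only a limit. The series as a whole offers (the limit of > 21500 nM in this assay, at which 3 of the 3 values shown sit). In compound 4 `CCOC(=O)c1c(-c2cccc(-c3c(C)cccc3C)c2)[nH]c2cc(OC)c(F)cc2c1=O`, 2,6-dimethylphenyl takes the place of bromo on an aromatic carbon (2,6-dimethylphenyl in place of bromo on an aromatic carbon).

The closest measured comparison is a step that the two limits leave unreadable from compound 1 to compound 3, where bromo replaces phenoxy at the same place. Also relevant are a step that the two limits leave unreadable from compound 1 to compound 2 and a step that the two limits leave unreadable from compound 2 to compound 3. None of these steps has a readable size, so the series shows no measured effect of changing this group. Compound 1, which carries phenoxy there, also sits at > 21500 nM, a limit.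

The expected outcome in this assay is no shift beyond the scatter, with no direction assigned. The estimated step is a number no higher from compound 3 to compound 4 (the limit leaves the size open). The estimated value for compound 4 is 21500 nM, with an expected range of 11000 nM to 30000 nM.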

Compound 4, half-maximal effective concentration: > 21500 nM
Compound 4: no number, only a limit; the forecaster's own chance of this, stated with the estimate: 85%; the middle value lies on the limit itself.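

In this assay compound 4 gives > 21500 nM, a limit, so its steps from compound 1, compound 2 and compound 3 cannot be read. The compounds shown leave open where any of them would have an effect in this assay, and whether changing this group alters the read-out at all.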